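The source may report more compounds than this note shows. Statements on the series, on what has been measured and on what is new or still open speak of the compounds shown alone.

Measured so far in an ADME assay on microsomes from liver (Homo sapiens) for metabolic stability, read by LC-MS, using NADPH, with stated times of 5 min and 30 min, tested at 1 uM; a lower number here means slower removal, a higher number faster removal of the compound:
- compound 1 `O=C(Nc1ccccc1)c1cnc(NCc2c(F)ccc3c2CCO3)n2cnnc12` gives 14 mL.min-1.g-1
- compound 2 `O=C1c2ccccc2CN1c1cnc(NCc2c(F)ccc3c2CCO3)n2cnnc12` gives 13 mL.min-1.g-1
- compound 3 `COCCC(=O)Nc1cnc(NCc2c(F)ccc3c2CCO3)n2cnnc12` gives < 3 mL.min-1.g-1 as a limit of the assay, not a number

Compound 3 stands at the limit of < 3 mL.min-1.g-1 in this assay, at which 1 of the 3 values shown sits, and has no exact number. Compound 4 `CN(c1ccccc1)c1cnc(NCc2c(F)ccc3c2CCO3)n2cnnc12` carries methyl(phenyl)amino in place of ((2-methoxyethyl)carbonyl)amino on an aromatic carbon, a change counted as methyl(phenyl)amino in place of ((2-methoxyethyl)carbonyl)amino on an aromatic carbon and no other.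

Going by the values given here, two measured steps bear on this change when taken in reverse: the data show an at least 4.6-fold lower number from compound 1 to compound 3 (0.66 log units; beyond the scatter) and an at least 4.3-fold lower number from compound 2 to compound 3 (0.63 log units; beyond the scatter) and both lie beyond the scatter. Each runs from a group with a six-membered aromatic ring of carbon only to the open chain of compound 3, and compound 4 regains such a ring. The step of a 1.1-fold lower number from compound 1 to compound 2 (0.03 log units; within the scatter) lies within the scatter, so these two ring-bearing groups show no difference.

In this assay a rise of similar size is therefore expected, beyond the scatter, towards the level of compound 1 and compound 2. The expected move is an at least 5.0-fold higher number from compound 3 to compound 4 (0.69 log units; beyond the scatter) in this estimate. For compound 4 the estimated value is 15 mL.min-1.g-1 with an expected range from 6 mL.min-1.g-1 to 35 mL.min-1.g-1.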

Compound 4, intrinsic clearance in microsomes: 55 mL.min-1.g-1
Beside the measured number, compound 4's estimate is 3.7-fold (0.56 log units) below it; the whole stated range lies below it.
By their numbers in this assay, from the lowest: compounds 2 and 1 (each within the scatter of the next); then compound 4. At a limit, below all of these: compound 3.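

Three groups on this aromatic carbon now carry a six-membered aromatic ring of carbon only, and they no longer read alike in this assay: methyl(phenyl)amino gives a 3.9-fold higher number from compound 1 to compound 4 (0.59 log units; beyond the scatter) and a 4.2-fold higher number from compound 2 to compound 4 (0.63 log units; beyond the scatter), so that ring alone does not set the level. Going by these compounds alone, the span at this position is also wider than the earlier compounds showed, with an at least 18-fold higher number from compound 3 to compound 4 (1.26 log units; beyond the scatter). Compound 3 holds only a limit of the assay, not a number: the limit of < 3 mL.min-1.g-1 in this assay, at which 1 of the 4 values shown sits.

On these data alone, what remains open is which part of methyl(phenyl)amino goes with the higher number, the methyl or the phenyl. A phenylamino group without the methyl, or a pyridine ring in place of the phenyl, would bear on this at the same carbon.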